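The compounds below may be only part of what the source reports. "The series", "measured", "known", "first", "only" and "open" are said of these compounds alone.

Measured in a functional assay on PC-3 cells (Homo sapiens) for cytotoxicity, read by MTT assay, with a stated time of 72 h; a higher number here means a weaker inhibitor, a lower number a stronger inhibitor:

Compound 1 `COc1ccc(/C=C/C(O)=C/C(=O)/C=C/C2=C(C)CCCC2(C)C)cn1` gives 52200 nM.
Compound 2 `CC1=C(/C=C/C(=O)/C(=C\c2ccc(O)cc2)C(=O)/C=C/c2ccc(O)cc2)C(C)(C)CCC1` gives 6700 nM.

Both compounds share a long chain with two carbonyl-bearing stretches and a trimethylcyclohexenyl end, and in this assay compound 1 stands at the higher of the two numbers; the number of compound 2 is lower, and that gap lies beyond the usual scatter of the measurement, so compound 2 is the stronger inhibitor of the pair.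

Compound 3 `COc1cc(/C=C/C(O)=C/C(=O)/C=C/C2=C(C)CCCC2(C)C)ccc1O` has not been measured. It differs from compound 1 in one place: 4-hydroxy-3-methoxyphenyl in place of 6-methoxypyridin-3-yl on a double-bonded chain carbon bound to a double-bonded chain carbon. Going by the values given here, no step between measured compounds shows what this particular swap does, so the expectation rests on compound 1 alone and must stay cautious. A modest move toward a lower number, roughly at the edge of the scatter, is expected, as a 2.1-fold lower number from compound 1 to compound 3 (0.32 log units; beyond the scatter). On that basis compound 3 is estimated at 25000 nM in this assay, within a range from 8000 nM to 70000 nM.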

Compound 3, half-maximal inhibitory concentration: 15800 nM
Compound 3: the middle estimate sits 1.6-fold (0.20 log units) above what was measured; low and high end bracket the measured number.
By their numbers in this assay, from the lowest: compound 2; then compound 3; then compound 1.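

Swapping 6-methoxypyridin-3-yl for 4-hydroxy-3-methoxyphenyl gives, in this assay, a 3.3-fold lower number from compound 1 to compound 3 (0.52 log units; beyond the scatter), so the aromatic group on this double-bonded chain carbon can shift the number beyond the usual scatter. The entering group differs from the leaving one in several ways at once: its ring is of carbon only, and it has 1 hydrogen-bond donor where the leaving group has 0 hydrogen-bond donors, so this single step cannot separate these differences. Nothing at hand explains the shift.

Going by these compounds, it remains open whether a ring carrying an amine or a carboxylic acid at this position would give a lower or a higher number. On these data alone, a plain phenyl ring with only a methoxy group would help show whether the hydroxy group matters to the step, and that too remains open.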